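This account rests on a few compounds, and the source may have more. Where it says the series, first, only, none or still open, it means among the compounds named here.

Compound 1 `COc1ccc(Cl)cc1-n1ncc(-c2nnc(-c3cccc(F)c3)o2)c1C` is the starting point of this account. Going by the values given here, in a physicochemical assay for lipophilicity, using the shake flask method, measured as octanol-water partition (on this read-out lower numbers stand for lower lipophilicity and higher numbers for higher lipophilicity), compound 1 gives 4.28, the lowest of the three numbers measured so far: compound 2 `COc1ccc(Cl)cc1-n1ncc(-c2nnc(-c3ccc(Br)c(C)c3)o2)c1C` gives 5.2 and compound 3 `COc1ccc(Cl)cc1-n1ncc(-c2nnc(-c3cc(Cl)cc(Cl)c3)o2)c1C` gives 5.61. The change now considered is 3,4-dichlorophenyl in place of 3-fluorophenyl on an aromatic carbon, which leads to compound 4 `COc1ccc(Cl)cc1-n1ncc(-c2nnc(-c3ccc(Cl)c(Cl)c3)o2)c1C`. Among the compounds with values here, two measured steps bear on it: a number 0.92 log units higher from compound 1 to compound 2 (beyond the scatter) and, closer in kind, a number 1.33 log units higher from compound 1 to compound 3 (beyond the scatter); the further step a number 0.41 log units higher from compound 2 to compound 3 (beyond the scatter) points the same way. A rise well beyond the scatter is therefore expected for compound 4 in this assay, of about the size seen with the other dichlorophenyl. The step expected is a number 1.22 log units higher from compound 1 to compound 4 (beyond the scatter). Compound 4 is estimated at 5.5, within a range from 5.1 to 5.9.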

Compound 4, partition coefficient: 5.57
For compound 4 the middle estimate is 0.07 log units below the measured one, and the stated range covers the measured number.
By their numbers in this assay, from the lowest: compound 1; then compound 2; then compounds 4 and 3 (each within the scatter of the next).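

In this assay the two dichlorophenyl groups cannot be told apart at this aromatic carbon: a number 0.04 log units lower from compound 3 to compound 4 (within the scatter) is the whole of the difference between them, so moving one chlorine changes nothing measurable here. The change from 3-fluorophenyl gives a number 1.29 log units higher from compound 1 to compound 4 (beyond the scatter) and the change from 4-bromo-3-methylphenyl gives a number 0.37 log units higher from compound 2 to compound 4 (beyond the scatter) in the same direction. Nothing shown here gives a reason for these steps.

As far as these compounds go, how a monochlorophenyl, or a phenyl carrying an amine or a carboxylic acid, would read at this carbon remains open.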